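Swapping Phenyl for an Oxazole on the Carbonyl

A few compounds are considered here, and "the series" means these few. Any claim that something is new, unique, unknown or untested is made for them only; others in the source may bear on it.

Within the data shown here, in an ADME assay on microsomes (Homo sapiens) for metabolic stability (on this read-out lower numbers stand for a shorter-lived compound and higher numbers for a longer-lived compound), compound 1 `O=C(c1ccccc1)N1CCC(C(=O)N2N=CCC2c2ccccc2)CC1` gives 1.72 h, the only exact number so far. Compound 2 `O=C(c1cnco1)N1CCC(C(=O)N2N=CC[C@H]2c2ccccc2)CC1` reads > 3 h in this assay, and this is a limit of the assay, not a number. The next compound to be measured is compound 3 `O=C(c1cocn1)N1CCC(C(=O)N2N=CCC2c2ccccc2)CC1`, which differs from compound 1 at a single place 1,3-oxazol-4-yl in place of phenyl on a carbonyl carbon: 1,3-oxazol-4-yl stands in place of phenyl on a carbonyl carbon. Among the measured compounds shown here, no step between measured compounds is available to size this change, so the expectation is only tentative. For the measured compounds named here, it leans on compound 2, whose limit of > 3 h is the one other reading to hand. The expected step is a 1.6-fold higher number from compound 1 to compound 3 (0.21 log units; within the scatter), upward in this assay but not expected to clear the usual scatter. For compound 3 the estimated value is 2.8 h, with an expected range from 1.6 h to 4.8 h.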

Compound 3, half-life: > 2.75 h
Compound 3 ended at the assay's limit; the forecaster's own chance of this, stated with the estimate: 45%; the middle value lies beyond the limit too.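

In this assay, among these compounds, the change from phenyl to 1,3-oxazol-4-yl on a carbonyl carbon gives the first step that can be read at this place: an at least 1.5-fold higher number from compound 1 to compound 3 (0.20 log units; that floor lies within the scatter). As far as these compounds go, the swap therefore shows no loss of half-life, but this floor alone does not establish a gain beyond the usual scatter, and the true size of the step remains unknown. Compound 3 gives a limit and not a number: the limit of > 2.75 h in this assay, at which 1 of the 3 values shown sits.

Among the compounds shown here, how far the step extends remains open, and compound 2 differs from compound 1 in more than one place, so the two give no step that can be read. From the compounds shown here alone, it is also open whether other groups on this carbonyl, such as a pyridine ring or a simple methyl, would read the same way.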